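Fluoro in place of bromo on the shared core

A few compounds are considered here, and "the series" means these few. Any claim that something is new, unique, unknown or untested is made for them only; others in the source may bear on it.

- compound 1 (`Cn1c(/C=C2/C(=O)Nc3ccc([N+](=O)[O-])cc32)nc2ccccc21`): (> 50000 nM), a limit, not a number
- compound 2 (`Cn1c(/C=C2/C(=O)Nc3ccc(Br)cc32)nc2ccccc21`): (41200 nM)

Among the compounds with values here, these values come from a functional assay on A549 cells (Homo sapiens) for cytotoxicity, read by MTT assay, with a stated time of 48 h (a lower number here means a stronger inhibitor, a higher number a weaker inhibitor), and compound 2 holds the only true number among them (41200 nM). Compound 1 stands at a limit (the limit of > 50000 nM in this assay, at which 1 of the 2 values shown sits).

Compound 3 (`Cn1c(/C=C2/C(=O)Nc3ccc(F)cc32)nc2ccccc21`) carries fluoro in place of bromo on an aromatic carbon. Within the data shown here, one measured step bears on that same carbon, bromo in place of nitro (an at least 1.2-fold lower number from compound 1 to compound 2 (0.08 log units; that floor lies within the scatter)). On these data alone, it is bounded by a limit, so its true size stays open. Among the measured compounds shown here, with that step as the only guide, no shift beyond the scatter is expected in this assay in either direction, and a reading at the limit remains possible. The estimated step is small (a 1.1-fold higher number from compound 2 to compound 3 (0.04 log units; within the scatter)). The expected value for compound 3 is (45000 nM), with an estimated range of (20000 nM to 80000 nM).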

Compound 3, half-maximal inhibitory concentration: 34600 nM
The estimate for compound 3 lay 1.3-fold (0.11 log units) above the measured number; the measured number falls inside the stated range.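

In this assay, fluoro in place of bromo on this aromatic carbon gives a 1.2-fold lower number from compound 2 to compound 3 (0.08 log units; within the scatter), so the two halogens cannot be told apart at this position. Set against nitro, fluoro gives an at least 1.4-fold lower number from compound 1 to compound 3 (0.15 log units; that floor lies within the scatter), so fluoro, like bromo before it, is not separated from nitro on the numbers shown. Compound 1 stands at a limit, not a number, and the true size of both steps from it stays open: the limit of > 50000 nM in this assay, at which 1 of the 3 values shown sits.

The compounds shown leave open whether any group on this carbon can move the number beyond the scatter. On these data alone, an amine, a methoxy group or a carboxylic acid in the same place would put that question to the test, while the true value of compound 1 remains unknown.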